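The compounds below may be only part of what the source reports. "The series", "measured", "known", "first", "only" and "open" are said of these compounds alone.

In a functional assay on A549 cells (Homo sapiens) for cytotoxicity, read by XTT assay, with a stated time of 24 h (on this read-out lower numbers stand for stronger inhibition and higher numbers for weaker inhibition), the three measured compounds gave these numbers: compound 1 `Cn1nnnc1SCC(=O)N/N=C/c1ccc([N+](=O)[O-])cc1` gave 632000 nM; compound 2 `Cn1nnnc1SCC(=O)N/N=C/c1ccc(Cl)cc1` gave 100000 nM; compound 3 `CC(C)c1ccc(/C=N/NC(=O)CSc2nnnn2C)cc1` gave 400000 nM.

Compound 3 thus holds the second highest number of the three: its number lies within the scatter of that of compound 1, while the step of a 4.0-fold higher number from compound 2 to compound 3 (0.60 log units; beyond the scatter) is beyond the scatter. Compound 4 `Cn1nnnc1SCC(=O)N/N=C/c1ccc(C(F)(F)F)cc1` differs from compound 3 by trifluoromethyl in place of isopropyl on an aromatic carbon. Going by the values given here, no measured step swaps exactly these two groups, but the changes at the same aromatic carbon bear on it: a 1.6-fold lower number from compound 1 to compound 3 (0.20 log units; within the scatter) stayed within the scatter, whereas a 6.3-fold lower number from compound 1 to compound 2 (0.80 log units; beyond the scatter) and a 4.0-fold higher number from compound 2 to compound 3 (0.60 log units; beyond the scatter) were modest steps beyond it. A modest shift, more likely downward, is therefore expected, a 1.6-fold lower number from compound 3 to compound 4 (0.20 log units; within the scatter). Compound 4 is expected to give 250000 nM, with a range from 80000 nM to 800000 nM.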

Compound 4, half-maximal inhibitory concentration: 6320000 nM
Compound 4: middle estimate off by 25-fold (1.40 log units), on the low side; the measured number lies above the stated range.
By their numbers in this assay, from the lowest: compound 2; then compounds 3 and 1 (each within the scatter of the next); then compound 4.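

Trifluoromethyl is the first group at this aromatic carbon to weaken inhibition this sharply: the change is large from isopropyl (a 16-fold higher number from compound 3 to compound 4 (1.20 log units; beyond the scatter)) and from chloro (a 63-fold higher number from compound 2 to compound 4 (1.80 log units; beyond the scatter)), and modest from nitro (a 10-fold higher number from compound 1 to compound 4 (1.00 log units; beyond the scatter)). Going by these compounds alone, changing the group at this carbon can therefore move the number further than the earlier compounds showed. Nothing available explains this jump. From the compounds shown here alone, it remains open whether the loss is special to trifluoromethyl or also comes with other groups here, such as an amine, a methoxy group or a single fluorine atom.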